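The source may report more compounds than this note shows. Statements on the series, on what has been measured and on what is new or still open speak of the compounds shown alone.

Compound 1 `CC(C)c1onc(-c2c(Cl)cccc2Cl)c1COc1ccc(-c2ccc3c(C(=O)O)ccnc3c2)cc1`: 560 nM
Compound 2 `CC(C)c1onc(-c2c(Cl)cccc2Cl)c1COc1ccc(-c2ccc3cc(C(=O)O)ncc3c2)cc1`: 77 nM
Compound 3 `COc1cc(C(=O)O)nc2ccc(-c3ccc(OCc4c(-c5c(Cl)cccc5Cl)noc4C(C)C)cc3)cc12`: 17 nM

In a functional assay on CV-1 cells for agonist activity at Bile acid receptor (Homo sapiens), read by a luciferase reporter (a lower number here means that less compound is needed, a higher number that more compound is needed for the effect), compound 3 gives the lowest number of the three. Its nearest neighbour, compound 2, sits higher by a margin beyond the usual scatter, and compound 1 lies further off still, so compound 3 is the most potent of the set measured so far.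

Compound 4 `CCCOc1cc(C(=O)O)nc2ccc(-c3ccc(OCc4c(-c5c(Cl)cccc5Cl)noc4C(C)C)cc3)cc12` differs from compound 3 in one place: ethyl in place of hydrogen on a saturated chain carbon bound to an oxygen on an aromatic ring, which, read one bond further out, turns the methoxy group into a propoxy group. For the measured compounds named here, no measured pair shows this change, so its effect can only be estimated. Compound 4 is expected to stay close to compound 3, with a step of a 1.3-fold higher number from compound 3 to compound 4 (0.11 log units; within the scatter) that may well lie within the scatter, giving an estimate of 22 nM in this assay, within 7 nM to 70 nM.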

Compound 4, half-maximal effective concentration: 22 nM
The estimate for compound 4 equals the measured number at the digits printed; low and high end bracket the measured number.
By their numbers in this assay, from the lowest: compounds 3 and 4 (each within the scatter of the next); then compound 2; then compound 1.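

In this assay the change from methoxy to propoxy gives a 1.3-fold higher number from compound 3 to compound 4 (0.11 log units; within the scatter) and so shows that this saturated chain carbon bound to an oxygen on an aromatic ring accepts an added ethyl without a change that stands beyond the scatter. Until now, only the methoxy group had been seen at this place. Nothing measured here offers an explanation for this tolerance. As far as these compounds go, whether it extends to a longer chain, or to a chain carrying an amine or a carboxylic acid, stays open.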